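Swapping the aryl group on the amide of compound 1

A few compounds are considered here, and "the series" means these few. Any claim that something is new, unique, unknown or untested is made for them only; others in the source may bear on it.

Compound 1 `Cc1cc(C)cc(NC(=O)CN2CCC(c3cccc[n+]3[O-])CC2)c1` is one of two anilide-type compounds tested in a functional assay on HEK293 cells for agonist activity at D(4) dopamine receptor (Homo sapiens), read by FLIPR (a higher number here means a larger maximal response, a lower number a smaller maximal response), where compound 1 gives 76%. Compound 2 `Cc1ccc(Cl)c(NC(=O)CN2CCC(c3cccc[n+]3[O-])CC2)c1Cl` gives 62%, so compound 1 holds the higher of the two values. Compound 3 `Cc1cc(Br)ccc1NC(=O)CN1CCC(c2cccc[n+]2[O-])CC1` carries 4-bromo-2-methylphenyl in place of 3,5-dimethylphenyl on an amide-type nitrogen. Within the data shown here, no measured pair shows a change of this kind, so the step from compound 1 to compound 3 is expected to be a modest decrease, roughly a number 8 percentage points lower from compound 1 to compound 3 (within the scatter), since the halogen-bearing compound 2 sits at 62%. Compound 3 is therefore estimated at 68%, within a range of 50% to 86%.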

Compound 3, largest response reached (reported as efficacy), in percent of the reference or control that the assay uses: 61%
Compound 3: the middle estimate sits 7 percentage points above what was measured; low and high end bracket the measured number.
By their numbers in this assay, from the lowest: compounds 3 and 2 (each within the scatter of the next); then compound 1.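

In this assay, putting 4-bromo-2-methylphenyl in place of 3,5-dimethylphenyl on the amide-type nitrogen gives a number 15 percentage points lower from compound 1 to compound 3 (beyond the scatter). This is the only pair shown that differs in one place, and it shows that the maximal response depends on the aryl group here, even with the same count of heavy atoms in both groups. No measurement available explains this step. From the compounds shown here alone, whether the bromine or the different placement of the methyl carries the step stays open, as does the response with an amine or a carboxylic acid on the aryl ring.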